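Swapping a hydroxy for a methyl on a chalcone

A few compounds are considered here, and "the series" means these few. Any claim that something is new, unique, unknown or untested is made for them only; others in the source may bear on it.

Measured so far in a functional assay on HeLa cells (Homo sapiens) for inhibition, read by MTT assay, with a stated time of 72 h; on this read-out lower numbers stand for stronger inhibition and higher numbers for weaker inhibition:
compound 1 `COc1cc(OC)c(OC)cc1/C=C/C(=O)c1c(OC)cc(O)c(CC=C(C)C)c1O` — > 50000 nM
compound 2 `COc1ccc(/C=C/C(=O)c2c(O)cc(O)cc2OC)cc1OC` — 49500 nM
compound 3 `COc1cc(OC)c(C(=O)/C=C/c2ccc(O)cc2)c(OC)c1` — 40600 nM

The value of compound 1 is a limit of the assay, not a number (the limit of > 50000 nM in this assay, at which 1 of the 3 values shown sits). Compound 3 has the lowest of the two numbers, and compound 2 sits so close that the two cannot be told apart. Compound 4 `COc1cc(OC)c(C(=O)/C=C/c2ccc(C)cc2)c(OC)c1` is not yet measured. It differs from compound 3 in one place (methyl in place of hydroxy on an aromatic carbon), on an aromatic carbon of a six-membered aromatic ring of carbon only. Within the data shown here, no measured pair shows this change, so the expected step of a 1.1-fold higher number from compound 3 to compound 4 (0.04 log units; within the scatter) is small, with no direction beyond the scatter. For compound 4 the estimate is 45000 nM, between 15000 nM and 150000 nM.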

Compound 4, half-maximal inhibitory concentration: 17000 nM
The estimate for compound 4 lay 2.6-fold (0.42 log units) above the measured number; measured number inside the range.
By their numbers in this assay, from the lowest: compound 4; then compounds 3 and 2 (each within the scatter of the next). At a limit, above all of these: compound 1.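

Methyl in place of hydroxy, para to a large group, gives a 2.4-fold lower number from compound 3 to compound 4 (0.38 log units; beyond the scatter), the first step in this series that can be read beyond the scatter. The hydroxy, with its hydrogen-bond donor, is therefore not required at this position for inhibition in this assay, and removing it leaves the compound more active here. Nothing shown here explains why the number fell.

As far as these compounds go, whether an amine or a longer chain at this position would lower the number further stays open. So does whether the same swap would act alike on a different core.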